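Furoxan-coumarin series: acetamido to amino on the coumarin ring

A few compounds are considered here, and "the series" means these few. Any claim that something is new, unique, unknown or untested is made for them only; others in the source may bear on it.

Measured so far:
Compound 1 `COc1cc2ccc(=O)oc2cc1OCCCCOc1no[n+]([O-])c1S(=O)(=O)c1ccccc1` — 6140 nM
Compound 2 `COc1cc2cc(NC(C)=O)c(=O)oc2cc1OCCCCOc1no[n+]([O-])c1S(=O)(=O)c1ccccc1` — 7190 nM

In a functional assay on A549 cells (Homo sapiens) for inhibition, read by MTT assay, with a stated time of 48 h (a lower number here means a stronger inhibitor, a higher number a weaker inhibitor), compound 1 gives 6140 nM and compound 2 gives 7190 nM. Among the measured compounds shown here, the one measured step, a 1.2-fold higher number from compound 1 to compound 2 (0.07 log units; within the scatter), puts acetamido in place of hydrogen on an aromatic carbon of the shared core. Compound 2 therefore gives the higher of the two numbers, but its gap to compound 1 lies within the scatter, so the two compounds cannot be told apart in this assay.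

Compound 3 `COc1cc2cc(N)c(=O)oc2cc1OCCCCOc1no[n+]([O-])c1S(=O)(=O)c1ccccc1` has not yet been measured. It differs from compound 2 by hydrogen in place of acetyl on a nitrogen on an aromatic ring. For the measured compounds named here, no measured step removes an acetyl from this nitrogen, so the only guide is that adding the whole acetamido group in a 1.2-fold higher number from compound 1 to compound 2 (0.07 log units; within the scatter) changed nothing beyond the scatter; the acetyl alone is a part of that group. The expectation is therefore a step of a 1.1-fold lower number from compound 2 to compound 3 (0.04 log units; within the scatter), that is none beyond the scatter. Compound 3 is estimated at 6500 nM, with a range from 3000 nM to 15000 nM.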

Compound 3, half-maximal inhibitory concentration: 5030 nM
For compound 3 the middle estimate is 1.3-fold (0.11 log units) above the measured one, within the range that was stated.
By their numbers in this assay, from the lowest: compounds 3, 1 and 2 (each within the scatter of the next).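

In this assay, the step that takes the acetyl off the nitrogen on the aromatic ring, acetamido to amino, is a 1.4-fold lower number from compound 2 to compound 3 (0.16 log units; within the scatter), so the two groups cannot be told apart at this position. The comparison with the unsubstituted core reads the same way, at a 1.2-fold lower number from compound 1 to compound 3 (0.09 log units; within the scatter), which adds a second nitrogen-bearing group to the earlier acetamido result. Hydrogen, amino and acetamido on this aromatic carbon therefore all lie within the scatter of one another, and no measurement is available here that would account for this flat reading.

Three compounds at one position leave open whether any group on this aromatic carbon can produce a step beyond the scatter, for example a carboxylic acid, a dimethylamino group or a benzamido group. As far as these compounds go, it also remains open whether the same flat reading would hold with a longer or shorter chain joining the shared core to the sulfonyl-bearing ring, or with a phenyl sulfonyl group replaced by a methyl sulfonyl group.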